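This account rests on a few compounds, and the source may have more. Where it says the series, first, only, none or still open, it means among the compounds named here.

Of the compounds shown here, three sharing one core have been tested in a functional assay on BCG823 cells (Homo sapiens) for inhibition, read by MTT assay, with a stated time of 72 h; a lower number here means a stronger inhibitor, a higher number a weaker inhibitor. Compound 1 `CN(C(=O)NC(=O)c1ccc(F)c(F)c1)c1nc(C(F)(F)F)c(C(=O)N/N=C/c2ccc(C(F)(F)F)cc2)s1` gives 3.85 ug/mL, compound 2 `CN(C(=O)NC(=O)c1ccc(F)c(F)c1)c1nc(C(F)(F)F)c(C(=O)N/N=C/c2cccc(C(F)(F)F)c2)s1` gives 4.46 ug/mL, and compound 3 `CN(C(=O)NC(=O)c1ccc(F)c(F)c1)c1nc(C(F)(F)F)c(C(=O)N/N=C/c2ccc([N+](=O)[O-])cc2)s1` gives 2.99 ug/mL. Compound 1 holds the second highest of these three numbers, and its steps to the others, a 1.2-fold higher number from compound 1 to compound 2 (0.06 log units; within the scatter) and a 1.3-fold lower number from compound 1 to compound 3 (0.11 log units; within the scatter), both lie within the scatter, as does a 1.5-fold lower number from compound 2 to compound 3 (0.17 log units; within the scatter). Compound 4 `CN(C(=O)NC(=O)c1ccccc1F)c1nc(C(F)(F)F)c(C(=O)N/N=C/c2ccc(C(F)(F)F)cc2)s1` differs from compound 1 in a different part of the molecule: 2-fluorophenyl in place of 3,4-difluorophenyl on a carbonyl carbon. Among the measured compounds shown here, no measured step touches that part; the three known steps only vary the group on the carbon with a double bond to nitrogen, and all stay within the scatter. A step within the scatter is therefore expected, a 1.0-fold higher number from compound 1 to compound 4 (0.02 log units; within the scatter). Compound 4 is estimated at 4 ug/mL, with a range from 1.6 ug/mL to 10 ug/mL.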

Compound 4, half-maximal inhibitory concentration: 3.87 ug/mL
The estimate for compound 4 lay 1.0-fold (0.01 log units) above the measured number; low and high end bracket the measured number.
By their numbers in this assay, from the lowest: compounds 3, 1, 4 and 2 (each within the scatter of the next).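

Among the compounds shown here, replacing 3,4-difluorophenyl with 2-fluorophenyl on the carbonyl carbon gives a 1.0-fold higher number from compound 1 to compound 4 (0.00 log units; within the scatter) in this assay, the first measured step in this part of the molecule. At this level of resolution, the two groups cannot be told apart, so the result extends the flat picture seen at the group on the carbon with a double bond to nitrogen to this second position. No available measurement explains the result.

Only fluorophenyl groups appear on this carbonyl carbon here. As far as these compounds go, whether an unsubstituted phenyl, a cyclohexyl or an amine-bearing ring would keep the number in this range remains open.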